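A few compounds are considered here, and "the series" means these few. Any claim that something is new, unique, unknown or untested is made for them only; others in the source may bear on it.

Compound 1 `COc1ccc2c(=O)c(/C=C/C(=O)NCc3ccccc3)coc2c1`: 11800 nM
Compound 2 `COc1ccc2c(=O)c(/C=C/C(=O)Nc3ccccc3OC)coc2c1`: > 100000 nM
Compound 3 `COc1ccc2c(=O)c(/C=C/C(=O)Nc3cccc(C)c3)coc2c1`: > 100000 nM

In a functional assay on A549 cells (Homo sapiens) for inhibition, read by MTT assay, with a stated time of 48 h (a lower number here means a stronger inhibitor, a higher number a weaker inhibitor), compound 1 gives 11800 nM. Compound 2 reaches only the limit of this assay, > 100000 nM. Compound 3 also gives only a limit, > 100000 nM, so where it stands is known only as a limit, (the limit of > 100000 nM in this assay, at which 2 of the 3 values shown sit).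

Compound 4 `COc1ccc2c(=O)c(/C=C/C(=O)Nc3ccccc3C)coc2c1` differs from compound 3 in one place: 2-methylphenyl in place of 3-methylphenyl on an amide-type nitrogen. The measured steps that bear on this change are an at least 8.4-fold higher number from compound 1 to compound 3 (0.92 log units; beyond the scatter) and an at least 8.4-fold higher number from compound 1 to compound 2 (0.92 log units; beyond the scatter); both aryl amides sit at the limit, and a step that the two limits leave unreadable from compound 2 to compound 3. Compound 4 is therefore expected to remain at or near that limit, estimated at 100000 nM, in the range 30000 nM to 300000 nM. That estimate means a number no higher from compound 3 to compound 4 (the limit leaves the size open), which is expected to stay within the scatter.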

Compound 4, half-maximal inhibitory concentration: 23400 nM
For compound 4 the middle estimate is 4.3-fold (0.63 log units) above the measured one; measured number below the stated range.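

In this assay, moving the methyl group from 3-methylphenyl to 2-methylphenyl on the amide-type nitrogen gives an at least 4.2-fold lower number from compound 3 to compound 4 (0.63 log units; beyond the scatter), so activity here depends on where that methyl sits. Methyl in place of methoxy on an aromatic carbon gives an at least 4.2-fold lower number from compound 2 to compound 4 (0.63 log units; beyond the scatter). Replacing benzyl with 2-methylphenyl gives a 2.0-fold higher number from compound 1 to compound 4 (0.30 log units; within the scatter), so not every aryl amide shown sits at the limit.

The true size of the first two steps stays open, because compound 2 and compound 3 carry only limits: the limit of > 100000 nM in this assay, at which 2 of the 4 values shown sit.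

On these data alone, whether a 2-ethylphenyl or 2-chlorophenyl group would behave like 2-methylphenyl also remains open.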